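Swapping a benzyl for a cyclopentyl on the shared core

The compounds below may be only part of what the source reports. "The series", "measured", "known", "first", "only" and "open" are said of these compounds alone.

Of the compounds shown here, two built on the same core have been tested in a functional assay on cells (T-cell, Homo sapiens) for inhibition; on this read-out higher numbers stand for weaker inhibition and lower numbers for stronger inhibition. Going by the values given here, compound 1 `COc1ccc(-c2cnc3nc(N)nc(NCc4ccccc4)c3n2)cc1OC` is the weaker of the two: in this assay compound 1 gives 13000 nM, the highest of the numbers measured so far. Compound 2 `COc1ccc(-c2cnc3nc(N)nc(N4CCN(C(=O)c5ccccc5)CC4)c3n2)cc1OC` carries a different group on the core and in this assay compound 2 gives 400 nM, a gap from compound 1 that lies beyond the scatter.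

Compound 3 `COc1ccc(-c2cnc3nc(N)nc(NC4CCCC4)c3n2)cc1OC` differs from compound 1 in one place, (cyclopentyl in place of benzyl on a nitrogen on an aromatic ring), that is, benzylamino becomes cyclopentylamino. Among the compounds with values here, no measured pair shows what this particular exchange does, so the direction is uncertain. Given the weak starting point of compound 1 at 13000 nM, a small step in either direction, or none beyond the scatter, is expected a 1.4-fold lower number from compound 1 to compound 3 (0.16 log units; within the scatter). Compound 3 is therefore estimated at 9000 nM in this assay, with a range from 2500 nM to 30000 nM.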

Compound 3, half-maximal inhibitory concentration: 800 nM
Compound 3: the middle estimate sits 11-fold (1.05 log units) above what was measured, and the stated range ends above it.
By their numbers in this assay, from the lowest: compounds 2 and 3 (each within the scatter of the next); then compound 1.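

Exchanging benzyl for cyclopentyl on a nitrogen on an aromatic ring gives a 16-fold lower number from compound 1 to compound 3 (1.21 log units; beyond the scatter) in this assay, so with the rest of the molecule unchanged, this one group clearly shifts the result. The exchange alters several things at once: a six-membered aromatic ring becomes a five-membered non-aromatic ring, and the group goes from 7 heavy atoms to 5. Nothing available explains the size of this step.

Going by these compounds, it remains open which of these differences matters, since a single pair cannot separate them. Cyclohexyl would keep a six-membered ring without aromaticity and isopropyl would offer a smaller open chain, so either group on the same nitrogen could help to tell ring size, aromaticity and overall group size apart.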